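From isobutoxy to benzyloxy: one change on a shared core

The source may report more compounds than this note shows. Statements on the series, on what has been measured and on what is new or still open speak of the compounds shown alone.

Compound 1 `O=C(/C=C/c1ccc(O)cc1)c1c(O)cccc1OCCC1CCCCC1`: > 30000 nM (a limit)
Compound 2 `CC(C)COc1cccc(O)c1C(=O)/C=C/c1ccc(O)cc1`: 3290 nM

Going by the values given here, in a functional assay on ACHN cells (Homo sapiens) for antiproliferative activity, read by sulforhodamine B assay (on this read-out higher numbers stand for weaker inhibition of growth and lower numbers for stronger inhibition of growth), compound 2 gives 3290 nM, the only actual number so far. Compound 1 stands at > 30000 nM, which is a limit of the assay and not a number.

Compound 3 `O=C(/C=C/c1ccc(O)cc1)c1c(O)cccc1OCc1ccccc1` keeps the shared core and carries phenyl in place of isopropyl on a saturated chain carbon bound to an oxygen on an aromatic ring.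

Among the compounds with values here, only one measured step changes this same place: an at least 9.1-fold lower number from compound 1 to compound 2 (0.95 log units; beyond the scatter). Going by these compounds, it ends in a limit on one side, so its full size stays open. Compound 3 puts a ring back at that place, as compound 1 has, so some loss of growth inhibition seems likely, though probably less than that step.

The expected change is a 2.7-fold higher number from compound 2 to compound 3 (0.44 log units; beyond the scatter). For compound 3 the estimated value is 9000 nM, with an expected range of 3000 nM to 28000 nM.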

Compound 3, concentration for 50% growth inhibition: > 30000 nM
Compound 3: only a limit was reported (the forecaster's own chance of this, stated with the estimate: 15%); middle value at least 3.3-fold (0.52 log units) from the limit.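

In this assay, phenyl in place of isopropyl on a saturated chain carbon bound to an oxygen on an aromatic ring gives an at least 9.1-fold higher number from compound 2 to compound 3 (0.95 log units; beyond the scatter), so the loss of growth inhibition seen with the saturated ring of compound 1 also appears with the aromatic ring of compound 3. Going by these compounds, the value of compound 3, > 30000 nM, is a limit of the assay and not a number, so the full size of this loss stays open. The step between compound 1 and compound 3 cannot be read, and these two compounds cannot be ranked: the limit of > 30000 nM in this assay, at which 2 of the 3 values shown sit.

Among the compounds shown, only compound 2 gives an actual number, 3290 nM. On these data alone, whether a smaller group such as ethyl, or a chain ending in an amine, would give stronger or weaker inhibition of growth at this place remains open.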